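Aryl amine swap on the shared core: compound 1 to compound 4

The source may report more compounds than this note shows. Statements on the series, on what has been measured and on what is new or still open speak of the compounds shown alone.

Compound 1 `Cc1ccc(NC2=CC(=O)c3c(nc4n3[C@H]3OC[C@@H](O)[C@H]3OC4)C2=O)cc1C` carries a (3,4-dimethylphenyl)amino group on the shared core. In a functional assay on MGC-803 cells (Homo sapiens) for inhibition, read by sulforhodamine B assay (a lower number here means a stronger inhibitor, a higher number a weaker inhibitor), compound 1 gives 1050 nM. Compound 2 `CCc1ccc(NC2=CC(=O)c3nc4n(c3C2=O)[C@H]2OC[C@@H](O)[C@H]2OC4)cc1`, with a 4-ethylphenyl on the same amine nitrogen, gives 1290 nM, and compound 3 `O=C1C=C(Nc2cccc(Cl)c2)C(=O)c2c1nc1n2[C@H]2OC[C@@H](O)[C@H]2OC1`, with a 3-chlorophenyl there, gives 1770 nM. Compound 1 sits within the scatter of both compound 2 and compound 3, so no order among the three can be read from these numbers.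

Compound 4 `O=C1C(Nc2ccc(I)cc2)=CC(=O)c2c1nc1n2[C@H]2OC[C@@H](O)[C@H]2OC1` is the next aryl amine. The change from compound 1: 4-iodophenyl in place of 3,4-dimethylphenyl on an amine nitrogen. Among the measured compounds shown here, the one measured step that bears on such a swap of the aryl group on the amine nitrogen is a 1.4-fold higher number from compound 2 to compound 3 (0.14 log units; within the scatter), and it stayed within the scatter. On that basis, the step for compound 4 is expected to be no larger than the scatter, in no particular direction, meaning a 1.2-fold higher number from compound 1 to compound 4 (0.09 log units; within the scatter).

Compound 4 is therefore estimated at 1300 nM, with a range from 600 nM to 2800 nM.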

Compound 4, half-maximal inhibitory concentration: 2150 nM
For compound 4 the middle estimate is 1.7-fold (0.22 log units) below the measured one; measured number inside the range.
By their numbers in this assay, from the lowest: compounds 1, 2, 3 and 4 (each within the scatter of the next, the first and the last beyond it).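

In this assay, among the compounds shown here, 4-iodophenyl in place of 3,4-dimethylphenyl on the amine nitrogen gives a 2.0-fold higher number from compound 1 to compound 4 (0.31 log units; beyond the scatter), the first step at this position that lies beyond the scatter, though only modestly. The choice of aryl group on this nitrogen can therefore shift the number, yet compound 2 and compound 3 stay within the scatter of their neighbours in the order, so the four compounds form one continuous run and not separate groups. Nothing available explains this step.

The compounds shown leave open whether the step goes with the iodine or with the loss of the two methyl groups, which change together in this swap. Also open, from the compounds shown here alone, is whether an aryl group carrying an amine or a carboxylic acid, or a plain alkyl chain on this nitrogen, would fall outside this run.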